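Solubility notes: pyridinyl substitution on the piperidine of compound 3

The source may hold more compounds than are shown below. What is called first, only, known or untested is meant among the compounds shown, and "the series" means these compounds.

Compound 3 `COc1ccc2[nH]c(C(=O)N3CC(=O)N(Cc4cccc(OC(F)F)c4)[C@@H](CN4CCCCC4)C3)cc2c1` gives 26400 nM in a physicochemical assay for solubility, read by spectrophotometry, in phosphate buffer, with a stated time of 2 h, at pH 7.4 (on this read-out lower numbers stand for lower solubility and higher numbers for higher solubility), the lowest of the two numbers in hand; compound 2 `COc1ccc2[nH]c(C(=O)N3CC(=O)N(Cc4ccoc4)[C@@H](Cc4ccccc4)C3)cc2c1` gives 63600 nM, a difference beyond the scatter. Compound 1 `COc1ccc2[nH]c(C(=O)N3CC(=O)N(Cc4ccccc4)[C@@H](CN4CCCCC4)C3)cc2c1` reports only a limit, > 25000 nM. The step from compound 1 to compound 3 a step that the limit leaves unreadable from compound 1 to compound 3 cannot be sized because of the limit of > 25000 nM in this assay, at which 1 of the 3 values shown sits. Compound 4 `COc1ccc2[nH]c(C(=O)N3CC(=O)N(Cc4cccc(OC(F)F)c4)[C@@H](CN4CCC(c5ccccn5)CC4)C3)cc2c1` differs from compound 3 by pyridin-2-yl in place of hydrogen on a saturated ring carbon. Among the compounds with values here, no measured step touches that position, so no direction is supported, and the expectation for compound 4 is a step of a 1.3-fold lower number from compound 3 to compound 4 (0.12 log units; within the scatter) that stays within the scatter. Compound 4 is therefore estimated at 20000 nM, with a range from 7000 nM to 55000 nM.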

Compound 4, solubility: 11600 nM
The estimate for compound 4 lay 1.7-fold (0.24 log units) above the measured number; low and high end bracket the measured number.
By their numbers in this assay, from the lowest: compound 4; then compound 3; then compound 2.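

In this assay, within the data shown here, the change from piperidin-1-yl to 4-(pyridin-2-yl)piperidin-1-yl gives a 2.3-fold lower number from compound 3 to compound 4 (0.36 log units; beyond the scatter), the first readable step at this position. A ring placed on this saturated carbon, three ring bonds from the ring nitrogen, therefore moves the number downward, beyond the scatter. Nothing in hand accounts for the step. From the compounds shown here alone, whether a hydroxyl, a carboxylic acid or a pyridin-4-yl group at the same carbon moves the number in the same direction remains open. Steps resting on a limit cannot be read.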